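Swapping an Ether Arm for a Cyclic Ester in a Cytotoxicity Series

The compounds below may be only part of what the source reports. "The series", "measured", "known", "first", "only" and "open" are said of these compounds alone.

Measured compounds:
Compound 1 `CC(C)=CC[C@@H](OC[C@@H](C)O)C1=CC(=O)c2c(O)ccc(O)c2C1=O`: 22500 nM
Compound 2 `COCCO[C@H](CC=C(C)C)C1=CC(=O)c2c(O)ccc(O)c2C1=O`: 62400 nM
Compound 3 `CCCCC(CC(=O)O[C@H](CC=C(C)C)C1=CC(=O)c2c(O)ccc(O)c2C1=O)OC(C)=O`: 73500 nM

In a functional assay on HeLa cells (Homo sapiens) for cytotoxicity, read by MTT assay (a higher number here means a weaker inhibitor, a lower number a stronger inhibitor), compound 2 gives the second highest of the three numbers; its value and that of compound 3 lie within the scatter, while compound 1 sits clearly lower. Going by the values given here, the only step between single-change neighbours is a 2.8-fold higher number from compound 1 to compound 2 (0.44 log units; beyond the scatter). Compound 4 `CC(C)=CC[C@@H](OC(=O)C1CCCO1)C1=CC(=O)c2c(O)ccc(O)c2C1=O` differs from compound 2 as follows: (oxolan-2-yl)carbonyl in place of 2-methoxyethyl on an oxygen on a saturated carbon. Among the compounds with values here, no measured step tracks this exact change, but compound 3 also carries a carbonyl on an oxygen on a saturated carbon and its value does not separate from compound 2. Compound 4 is therefore expected to show a 1.0-fold higher number from compound 2 to compound 4 (0.02 log units; within the scatter), no shift beyond the scatter. The estimate for compound 4 is 65000 nM, ranging from 30000 nM to 140000 nM.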

Compound 4, half-maximal inhibitory concentration: 17000 nM
Beside the measured number, compound 4's estimate is 3.8-fold (0.58 log units) above it, outside the stated range (below it).
By their numbers in this assay, from the lowest: compounds 4 and 1 (each within the scatter of the next); then compounds 2 and 3 (each within the scatter of the next).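

Changing the group on this oxygen to (oxolan-2-yl)carbonyl gives a 3.7-fold lower number from compound 2 to compound 4 (0.56 log units; beyond the scatter) and shows that an ester here need not sit with the higher numbers, as compound 3 alone had suggested. The ring matters among the esters, since replacing 2-acetoxyhexyl on the carbonyl carbon gives a 4.3-fold lower number from compound 3 to compound 4 (0.64 log units; beyond the scatter) as a clear shift. The 2-hydroxypropyl ether stays level with this ester, with a 1.3-fold lower number from compound 1 to compound 4 (0.12 log units; within the scatter) inside the scatter. A plain acetyl on this oxygen, or an amine on the ring, would help separate the part played by the carbonyl from that of the ring. Nothing measured here explains these shifts.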